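Swapping halogenated aryl groups on a shared enone core

The source may report more compounds than this note shows. Statements on the series, on what has been measured and on what is new or still open speak of the compounds shown alone.

Compound 1 `O=C(/C(=C\c1cccc(Cl)c1Cl)SCc1ccc(Cl)cc1)c1ccc(Cl)cc1` gives 10000 nM in a functional assay on DU-145 cells (Homo sapiens) for inhibition, read by trypan blue exclusion, with a stated time of 96 h; a lower number here means a stronger inhibitor of growth, a higher number a weaker inhibitor of growth.
Compound 2 `Cc1ccc(CS/C(=C/c2c(O)cc(O)cc2O)C(=O)c2ccc(Cl)cc2)cc1` gives 50000 nM in this assay.
Compound 3 `Cc1ccc(CS/C(=C/c2ccccc2Br)C(=O)c2ccc(Cl)cc2)cc1` gives 10000 nM in this assay.

Compound 3 stands level with compound 1 at the digits shown, and the two together hold the lowest numbers of the three. Among the compounds with values here, its one neighbour with a single change is compound 2, and the step of a 5.0-fold lower number from compound 2 to compound 3 (0.70 log units; beyond the scatter) is modest but beyond the scatter. Compound 1 carries the same 2,3-dichlorophenyl group that is about to enter, yet its other aryl group differs from that of compound 3, so its value can only be read as a hint.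

Compound 4 `Cc1ccc(CS/C(=C/c2cccc(Cl)c2Cl)C(=O)c2ccc(Cl)cc2)cc1` has not yet been measured. The change from compound 3 is 2,3-dichlorophenyl in place of 2-bromophenyl on a double-bonded chain carbon bound to a double-bonded chain carbon. Within the data shown here, no measured step covers this exact exchange of one halogenated phenyl for another. Among the measured compounds shown here, the only step at hand, a 5.0-fold lower number from compound 2 to compound 3 (0.70 log units; beyond the scatter), concerns a different leaving group, and compound 1 shows that a 2,3-dichlorophenyl on a related core gave the same number as compound 3. On that basis the step of no change at the digits printed from compound 3 to compound 4 (within the scatter) is expected to stay within the scatter, and for compound 4 a value near 10000 nM is estimated, with a range of 4000 nM to 25000 nM in this assay.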

Compound 4, concentration for 50% growth inhibition: 25000 nM
The estimate for compound 4 lay 2.5-fold (0.40 log units) below the measured number, and the stated range covers the measured number.
By their numbers in this assay, from the lowest: compounds 1 and 3 (each within the scatter of the next); then compounds 4 and 2 (each within the scatter of the next).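

At this place, on a double-bonded chain carbon bound to a double-bonded chain carbon, one halogenated phenyl group could not simply stand in for another: in this assay the exchange of 2-bromophenyl for 2,3-dichlorophenyl gave a 2.5-fold higher number from compound 3 to compound 4 (0.40 log units; beyond the scatter) and so was a modest but real change. The 2,3-dichlorophenyl group also stayed close to the 2,4,6-trihydroxyphenyl group, with a 2.0-fold lower number from compound 2 to compound 4 (0.30 log units; within the scatter) as the printed step, so the separation that 2-bromophenyl showed from the trihydroxyphenyl group did not extend to this second halogenated phenyl. The 2,3-dichlorophenyl group also did not fix the number by itself, since methyl in place of chloro on an aromatic carbon gave a 2.5-fold higher number from compound 1 to compound 4 (0.40 log units; beyond the scatter) and the value at this place therefore depended on the rest of the molecule as well. No measurement available here accounts for any of these steps.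

Within the data shown here, with only three groups compared at this place on one core, it remains open whether the 2-bromophenyl number reflects the bromine itself or the single substituent on the ring. As far as these compounds go, it also remains open how a phenyl carrying an amine or a carboxylic acid would fall, and whether 2-bromophenyl would keep its number on the core of compound 1.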